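This account rests on a few compounds, and the source may have more. Where it says the series, first, only, none or still open, it means among the compounds named here.

Compound 1, `Oc1ccc(CC[C@H](O)C[C@@H](O)CCc2ccccc2)cc1`: 12.8 ug/mL
Compound 2, `Oc1ccc(CC[C@@H](O)C[C@@H](O)CCc2ccccc2)cc1`: 12.6 ug/mL
Compound 3, `COc1cc(CC[C@H](O)C[C@@H](O)CCc2ccccc2)ccc1O`: 42.7 ug/mL

All three were tested in a functional assay on THP-1 cells (Homo sapiens) for antiproliferative activity, read by MTT assay, with a stated time of 48 h; on this read-out lower numbers stand for stronger inhibition and higher numbers for weaker inhibition. Compound 3 gives the highest number of the three, so it is the weakest inhibitor here; its nearest neighbour is compound 1, and the step of a 3.3-fold higher number from compound 1 to compound 3 (0.52 log units; beyond the scatter) brings in a methoxy in place of hydrogen on an aromatic carbon.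

Compound 4, `COc1cc(CC[C@@H](O)C[C@@H](O)CCc2ccccc2)ccc1O`, has not yet been measured. It relates to compound 3 as follows: the two compounds have the same atoms and bonds and differ only in configuration as drawn: 1 of 2 stereo elements differ; a stereocentre at a saturated chain carbon is drawn S in compound 3 and R in compound 4. Among the compounds with values here, one measured step bears directly on this change: a 1.0-fold lower number from compound 1 to compound 2 (0.01 log units; within the scatter). That pair is a fair guide because the fact that compounds 1 and 2 differ only in the configuration as drawn makes it the same kind of change at the same kind of chain carbon, and there the number stayed within the scatter.

No step beyond the scatter is therefore expected in this assay. Compound 4 is expected to give about 42 ug/mL, within a range of 25 ug/mL to 75 ug/mL. The expected step from the measured parent is a 1.0-fold lower number from compound 3 to compound 4 (0.01 log units; within the scatter).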

Compound 4, half-maximal inhibitory concentration: 72.2 ug/mL
For compound 4 the middle estimate is 1.7-fold (0.24 log units) below the measured one, and the stated range covers the measured number.
By their numbers in this assay, from the lowest: compounds 2 and 1 (each within the scatter of the next); then compounds 3 and 4 (each within the scatter of the next).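

Changing the configuration at this saturated chain carbon gives a step within the scatter on the methoxy-bearing compounds too, in this assay: a 1.7-fold higher number from compound 3 to compound 4 (0.23 log units; within the scatter). The configuration at this carbon therefore has no readable effect in either pair, with or without the methoxy group. The methoxy change can now be read in both configurations, with a 5.7-fold higher number from compound 2 to compound 4 (0.76 log units; beyond the scatter), so the higher number it brought in the first pair appears again in the second, and the two steps agree: the same change on two cores in this assay, a 3.3-fold higher number (0.52 log units; beyond the scatter) from compound 1 to compound 3 and a 5.7-fold higher number (0.76 log units; beyond the scatter) from compound 2 to compound 4, 1.7-fold (0.23 log units) apart, within the scatter of two such steps.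

All four compounds carry either hydrogen or methoxy at that aromatic carbon, and a hydroxyl at the chain carbon. Going by these compounds, whether a fluorine or an ethoxy group on the ring, or a ketone in place of that hydroxyl, would leave the configuration equally without a readable effect remains open.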